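A few compounds are considered here, and "the series" means these few. Any claim that something is new, unique, unknown or untested is made for them only; others in the source may bear on it.

Compound 1 `COc1cccc(OC)c1C(=O)Nc1c[nH]nc1C(=O)NC1CC1` carries a cyclopropylcarbamoyl group on its core and is tested in an ADME assay on MRC5 cells (Homo sapiens) for inhibition, with a stated time of 72 h; a lower number here means that less compound is needed, a higher number that more compound is needed for the effect. In this assay compound 1 reaches only the assay's limit of > 50000 nM, not a number. Compound 3 `COc1cccc(OC)c1C(=O)Nc1c[nH]nc1C(=O)NC1CCN(C(=O)OC(C)(C)C)CC1` in this assay likewise stops at the limit of > 50000 nM. Compound 2 `CO[C@H]1CC[C@H](NC(=O)c2n[nH]cc2NC(=O)c2ccc(OC(F)F)cc2)CC1` gives 2500 nM in this assay. Compound 1 therefore stands at the limit of > 50000 nM in this assay, at which 2 of the 3 values shown sit, with no value of its own. Compound 4 `COC(=O)c1n[nH]cc1NC(=O)c1c(OC)cccc1OC` is the next compound: methoxy in place of cyclopropylamino on a carbonyl carbon. Among the measured compounds shown here, no measured pair shows such a change, so the step from compound 1 to compound 4 is expected to be none beyond the scatter, with a step that the limit leaves unreadable from compound 1 to compound 4 as the expected step. Compound 4 is accordingly expected to give 60000 nM in this assay, within 20000 nM to 200000 nM, most likely again only as a limit.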

Compound 4, half-maximal effective concentration: > 50000 nM
Compound 4 ended at the assay's limit (the forecaster's own chance of this, stated with the estimate: 80%); the middle value does not contradict the limit.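

In this assay, among the compounds shown here, compound 1 and compound 4 both stop at the assay's limit, so no step between them can be read. The compounds shown leave open whether methoxy in place of cyclopropylamino on a carbonyl carbon changes the value at all.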